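Chlorine to bromine on a hydroxyphenyl hydrazone

This account rests on a few compounds, and the source may have more. Where it says the series, first, only, none or still open, it means among the compounds named here.

Measured compounds:
- compound 1 `O=C(CSc1nnc(-c2ccncc2)o1)N/N=C/c1ccccc1O`: in a functional assay on SW 1116 cells (Homo sapiens) for cytotoxicity, read by MTT assay, with a stated time of 48 h (a lower number here means a stronger inhibitor, a higher number a weaker inhibitor), compound 1 gives 7380 nM
- compound 2 `O=C(CSc1nnc(-c2ccncc2)o1)N/N=C/c1cc(Cl)cc(Cl)c1O`: in this assay compound 2 gives 5030 nM

Compound 2 stands beside compound 1 rather than apart from it: the step of a 1.5-fold lower number from compound 1 to compound 2 (0.17 log units; within the scatter) is within the scatter, so the two cannot be told apart. Compound 3 `O=C(CSc1nnc(-c2ccncc2)o1)N/N=C/c1cc(Br)cc(Br)c1O` differs from compound 2 by 3,5-dibromo-2-hydroxyphenyl in place of 3,5-dichloro-2-hydroxyphenyl on a carbon with a double bond to nitrogen. Among the compounds with values here, the only step that bears on this is the one from compound 1 to compound 2, which added the two chlorines and stayed within the scatter; exchanging one halogen pair for another is expected to move the number even less. No step beyond the scatter is therefore expected in this assay. Compound 3 is estimated at 4500 nM, within 1800 nM to 11000 nM, which means an expected step of a 1.1-fold lower number from compound 2 to compound 3 (0.05 log units; within the scatter).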

Compound 3, half-maximal inhibitory concentration: 8570 nM
Beside the measured number, compound 3's estimate is 1.9-fold (0.28 log units) below it; the range from low to high includes it.
By their numbers in this assay, from the lowest: compounds 2, 1 and 3 (each within the scatter of the next).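

With the dibromo group, this assay shows a 1.7-fold higher number from compound 2 to compound 3 (0.23 log units; within the scatter) and a 1.2-fold higher number from compound 1 to compound 3 (0.06 log units; within the scatter) and so gives no way to tell the two halogen pairs apart, or either pair from plain 2-hydroxyphenyl. On a carbon with a double bond to nitrogen, chlorine and bromine pairs have so far produced no step beyond the scatter. Nothing available here explains this result. Still open, going by these compounds, is whether a methoxy group in place of the hydroxyl, or an amine or a carboxylic acid on this ring, would produce a step beyond the scatter.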